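A few compounds are considered here, and "the series" means these few. Any claim that something is new, unique, unknown or untested is made for them only; others in the source may bear on it.

Compound 1 `O=S(=O)(NCCCNCc1ccc(Cl)c(Cl)c1)c1cc(C(F)(F)F)cc(C(F)(F)F)c1` gives 2900 nM in a functional assay on BE(2)-C cells (Homo sapiens) for inhibition, read by MTT assay, with a stated time of 72 h; on this read-out higher numbers stand for weaker inhibition of growth and lower numbers for stronger inhibition of growth; compound 2 `COc1ccc(CNCCCNS(=O)(=O)c2cc(C(F)(F)F)cc(C(F)(F)F)c2)cc1OC` gives 3600 nM.

Compound 1 holds the lower of the two numbers, with compound 2 nearest at a 1.2-fold higher number from compound 1 to compound 2 (0.09 log units; within the scatter), a step that exchanges the whole aryl group. Compound 3 `O=S(=O)(NCCCNCc1ccc(Cl)cc1)c1cc(C(F)(F)F)cc(C(F)(F)F)c1` differs from compound 1 in one place: hydrogen in place of chloro on an aromatic carbon. For the measured compounds named here, no measured step removes a single chloro, and the only measured step lies within the scatter. A small change is therefore expected, a 1.4-fold higher number from compound 1 to compound 3 (0.14 log units; within the scatter), with no clear direction beyond the scatter. Compound 3 is estimated at 4000 nM, within a range from 1800 nM to 9000 nM.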

Compound 3, concentration for 50% growth inhibition: 2900 nM
The estimate for compound 3 lay 1.4-fold (0.14 log units) above the measured number, within the range that was stated.
By their numbers in this assay, from the lowest: compounds 1, 3 and 2 (each within the scatter of the next).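

In this assay, the first measured removal of a single chloro gives no change at the digits printed from compound 1 to compound 3 (within the scatter), so the 3,4-dichlorobenzyl and 4-chlorobenzyl groups cannot be told apart here. The exchange of 3,4-dimethoxyphenyl for 4-chlorophenyl gives a 1.2-fold lower number from compound 2 to compound 3 (0.09 log units; within the scatter), so all three aryl groups shown remain inside the scatter. Nothing available explains this result.

Open, as far as these compounds go, is whether a nitrile or fluoro on this aromatic carbon would move the number beyond the scatter. Also open, from the compounds shown here alone, is whether an unsubstituted benzyl group or a longer chain would do so.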